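Phenoxy to amino in the high-tolerance compounds

The source may report more compounds than this note shows. Statements on the series, on what has been measured and on what is new or still open speak of the compounds shown alone.

Measured in an ADME assay on Huh-7 cells (Homo sapiens) for cytotoxicity, read by MTT assay, with a stated time of 4 h, at 37 degrees C; a higher number here means that more compound is tolerated, a lower number that less compound is tolerated:
- compound 1 `Cn1c(=O)c(-c2c(Br)cccc2Br)cc2c(N)nc(Nc3ccccc3)nc21`: 800 nM
- compound 2 `CCCOCCNc1nc(Oc2ccccc2)nc2[nH]c(=O)c(-c3ccc(F)cc3)cc12`: 79800 nM
- compound 3 `O=C1Nc2nc(Oc3ccccc3)nc(On3nnc4ccccc43)c2CC1c1ccc(F)cc1`: 62700 nM

Compound 2 at 79800 nM and compound 3 at 62700 nM lie within the scatter of each other, and both lie far above compound 1 at 800 nM. Compound 4 `CCCOCCNc1nc(N)nc2[nH]c(=O)c(-c3ccc(F)cc3)cc12` differs from compound 2 by amino in place of phenoxy on an aromatic carbon, between two ring nitrogen atoms. Going by the values given here, no measured pair isolates this change. Compound 1 has no phenoxy and gives 800 nM, but it differs from compound 2 in several places, so it offers only a caution. A small downward step in this assay is expected, possibly none beyond the scatter. The expected change is a 1.6-fold lower number from compound 2 to compound 4 (0.20 log units; within the scatter). In this assay, compound 4 is estimated at 50000 nM, with an expected range of 12000 nM to 150000 nM.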

Compound 4, half-maximal cytotoxic concentration: 130000 nM
Compound 4: the middle estimate sits 2.6-fold (0.41 log units) below what was measured; low and high end bracket the measured number.
By their numbers in this assay, from the lowest: compound 1; then compounds 3, 2 and 4 (each within the scatter of the next, the first and the last beyond it).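

In this assay, amino in place of phenoxy on the aromatic carbon between two ring nitrogen atoms gives a 1.6-fold higher number from compound 2 to compound 4 (0.21 log units; within the scatter). With the (2-propoxyethyl)amino group and the rest of the core held fixed, this position therefore does not depend on the phenoxy ring for a high number. Nothing measured here accounts for the outcome.

Open, as far as these compounds go, is whether a methoxy or morpholine group on this carbon would stay within the scatter of compound 2. Also open, from the compounds shown here alone, is whether the same step holds with a shorter chain in place of the (2-propoxyethyl)amino group.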